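The source may hold more compounds than are shown below. What is called first, only, known or untested is meant among the compounds shown, and "the series" means these compounds.

Of the compounds shown here, two have been tested in a functional assay on HepG2 cells (Homo sapiens) for antiproliferative activity, read by MTT assay, with a stated time of 48 h; on this read-out lower numbers stand for stronger inhibition and higher numbers for weaker inhibition. Compound 1, `N#CC1=C(N)Oc2c(c3nc4ccccc4nc3c3ccccc23)C12C(=O)N(Cc1cnnn1-c1ccc(Cl)c(Cl)c1)c1ccccc12`, gives > 50000 nM in this assay, a value that is a limit of the assay rather than a number. Compound 2, `N#CC1=C(N)Oc2c(N)cc3nc4ccccc4nc3c2C12C(=O)N(Cc1cnnn1-c1cccc(Br)c1)c1ccccc12`, gives > 50000 nM in this assay, again a limit and not a number. Among the compounds with values here, compound 2 thus stands at the same point as the only other value shown, (the limit of > 50000 nM in this assay, at which 2 of the 2 values shown sit), so no order between the two compounds can be drawn and no step between measured compounds is available.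

Compound 3, `Cc1ccc(-n2nncc2CN2C(=O)C3(C(C#N)=C(N)Oc4c(N)cc5nc6ccccc6nc5c43)c3ccccc32)cc1C`, has not yet been measured. It differs from compound 2 in one place: 3,4-dimethylphenyl in place of 3-bromophenyl on an aromatic nitrogen.

Within the data shown here, with both measured compounds sitting at the limit, there is no measured step to guide an expectation, and the change is confined to the group on an aromatic nitrogen. Compound 3 is expected to stay near the same limit, with a step that the limit leaves unreadable from compound 2 to compound 3 that is expected to be none beyond the scatter. The value of compound 3 in this assay is estimated at 60000 nM, with an expected range from 20000 nM to 200000 nM.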

Compound 3, half-maximal inhibitory concentration: > 50000 nM
Compound 3: only a limit was reported (the forecaster's own chance of this, stated with the estimate: 80%); the middle value does not contradict the limit.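

No step can be read between compound 2 and compound 3, because both sit at the same limit in this assay and neither gives a number: the limit of > 50000 nM in this assay, at which 3 of the 3 values shown sit.

The compounds shown leave open whether 3,4-dimethylphenyl and 3-bromophenyl on the aromatic nitrogen differ at all in this assay, and what change to the shared core would bring a value inside the limit.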